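Swapping Cyclobutyl for an Oxanylethyl Chain: Solubility Outlook

This account rests on a few compounds, and the source may have more. Where it says the series, first, only, none or still open, it means among the compounds named here.

Going by the values given here, compound 1 `CN(C)C(=O)CN1CCC(c2cc3c(-c4ccc(=O)n(C5CCC5)c4)ccnc3[nH]2)CC1` is the more soluble of the two compounds measured so far. In a physicochemical assay for solubility, in phosphate buffer, at pH 7.4 (a lower number here means a less soluble compound, a higher number a more soluble compound), compound 1 gives > 1000000 nM, and this figure is a limit of the assay rather than a number. That reading is the one that sits at the limit of > 1000000 nM in this assay, at which 1 of the 2 values shown sits, so compound 1 stands at the top of the measured range. Among the compounds with values here, compound 2 `CC(=O)N1CCC(c2cc3c(-c4ccc(=O)n(C(C)C)c4)ccnc3[nH]2)CC1` differs from compound 1 in more than one place, and in this assay compound 2 gives 27000 nM; no single step links the two, so the pair only shows that the two values lie far apart.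

Compound 3 `CN(C)C(=O)CN1CCC(c2cc3c(-c4ccc(=O)n(CCC5CCOCC5)c4)ccnc3[nH]2)CC1` has not been measured. It differs from compound 1 by one change, (2-(oxan-4-yl)ethyl in place of cyclobutyl on an aromatic nitrogen), with 2-(oxan-4-yl)ethyl in place of cyclobutyl on the aromatic nitrogen. Within the data shown here, with no measured step of this kind to lean on, the expected step in this assay from compound 1 to compound 3 is a modest downward one, possibly no larger than the scatter, namely an at least 1.4-fold lower number from compound 1 to compound 3 (0.15 log units; that floor lies within the scatter). Compound 3 is therefore expected to give about 700000 nM, within a range from 150000 nM to 3000000 nM.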

Compound 3, solubility: 370000 nM
Compound 3: the middle estimate sits 1.9-fold (0.28 log units) above what was measured; low and high end bracket the measured number.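

Going by these compounds alone, on the aromatic nitrogen of the shared core, 2-(oxan-4-yl)ethyl in place of cyclobutyl gives, in this assay, an at least 2.7-fold lower number from compound 1 to compound 3 (0.43 log units; beyond the scatter), the first single-place step at this position. The true size of this step stays unknown, and only its floor is printed, because the reading for compound 1 is a limit of the assay and not a number: the limit of > 1000000 nM in this assay, at which 1 of the 3 values shown sits.

Compound 3 gives 370000 nM in this assay, so the larger group, with 8 heavy atoms against 4 and one hydrogen-bond acceptor against none, still leaves a real number that can serve as a reference for further changes at this position.

The compounds shown leave open which part of the change carries the step, since the chain, the ring size and the ring oxygen all change together, and a 2-cyclohexylethyl group, which has carbon in place of the ring oxygen, would separate the oxygen from the rest. Also open, going by these compounds, is what a chain ending in an amine or a carboxylic acid would give on this nitrogen, and whether the step holds with a different group on the other side of the core.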